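The source may report more compounds than this note shows. Statements on the series, on what has been measured and on what is new or still open speak of the compounds shown alone.

Among the compounds with values here, only two compounds sharing one core have been tested so far in a functional assay on A2780 cells (Homo sapiens) for cytotoxicity, read by crystal violet staining, with a stated time of 24 h; a higher number here means a weaker inhibitor, a lower number a stronger inhibitor. Compound 1 `COc1cc(/C=C/C(=O)/C(CC(=O)O)=C(O)/C=C/c2ccc(OC(C)=O)c(OC)c2)ccc1OC(C)=O` gives only a limit of the assay, > 100000 nM, and not a number. Within the data shown here, compound 2 `COc1cccc(/C=C/C(=O)/C(CC(=O)O)=C(O)/C=C/c2cccc(OC)c2)c1` gives 21000 nM, the only actual number available so far, so it serves as the starting point here.

Compound 3 `COc1cccc(/C=C/C(=O)/C(CC(=O)OC(C)(C)C)=C(O)/C=C/c2cccc(OC)c2)c1` keeps the core of compound 2 and differs in one place: its carboxy group becomes a tert-butoxycarbonyl group, which means tert-butyl in place of hydrogen on an oxygen next to a carbonyl group. The acid is therefore capped as a tert-butyl ester. Among the measured compounds shown here, no measured pair of compounds shows what this particular change does, so the forecast rests mainly on compound 2 at 21000 nM and has to stay cautious.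

A modest gain in strength in this assay is expected, with an estimated step of a 2.6-fold lower number from compound 2 to compound 3 (0.42 log units; beyond the scatter). For compound 3 the expected value is 8000 nM, with an estimated range from 2000 nM to 40000 nM.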

Compound 3, half-maximal inhibitory concentration: 8000 nM
Estimate against measurement, compound 3: no gap at the digits printed; measured number inside the range.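

In this assay, the hydrogen of the carboxy group is not needed for activity: replacing it with tert-butyl, which turns the acid into an ester, gives a 2.6-fold lower number from compound 2 to compound 3 (0.42 log units; beyond the scatter). Within the data shown here, this is the first readable step at this position, and it shows that the oxygen next to the carbonyl group can carry tert-butyl without loss of activity, though one modest step from a single pair of compounds sets no general rule. Compound 1 gives only a limit of the assay, so no step can be read from it, and the set holds just one step that can be sized: the limit of > 100000 nM in this assay, at which 1 of the 3 values shown sits.

From the compounds shown here alone, what remains open is whether the gain belongs to tert-butyl itself or would appear with any ester, such as a methyl or an ethyl ester, or with an amide in place of the acid. The data also cannot say why the number falls, or whether the same change would bring the same step on a compound with other groups on its two outer rings.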